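A 2-chlorophenyl swap on compound 2

The source may hold more compounds than are shown below. What is called first, only, known or untested is meant among the compounds shown, and "the series" means these compounds.

Compound 1 (`O=C(CCCCCCc1nc(-c2ccccc2Cl)no1)NO`), 10300 nM
Compound 2 (`Nc1ccccc1NC(=O)CCCCCCc1nc(-c2ccc(C(F)(F)F)cc2)no1`), 29800 nM

Both compounds were measured in a functional assay on NCI-H661 cells (Homo sapiens) for antiproliferative activity, read by MTT assay, with a stated time of 72 h (a lower number here means a stronger inhibitor, a higher number a weaker inhibitor), and compound 2 holds the higher of the two numbers, with a gap to compound 1 that lies beyond the scatter.

Compound 3 (`Nc1ccccc1NC(=O)CCCCCCc1nc(-c2ccccc2Cl)no1`) has not yet been measured. It departs from compound 2 in a single place (2-chlorophenyl in place of 4-(trifluoromethyl)phenyl on an aromatic carbon), with 2-chlorophenyl in place of 4-(trifluoromethyl)phenyl on an aromatic carbon. Among the measured compounds shown here, no measured pair shows this swap on its own. The same 2-chlorophenyl is carried by compound 1 at 10300 nM but that compound also differs from compound 3 elsewhere, so it offers only a loose guide. Compound 2 at 29800 nM remains the closer reference. In this assay the expectation is therefore no step beyond the scatter, with an estimated 1.4-fold lower number from compound 2 to compound 3 (0.15 log units; within the scatter) as the likely size. The estimate for compound 3 is 21000 nM (expected range 8000 nM to 50000 nM).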

Compound 3, half-maximal inhibitory concentration: 8310 nM
Compound 3: the middle estimate sits 2.5-fold (0.40 log units) above what was measured, and the stated range covers the measured number.
By their numbers in this assay, from the lowest: compounds 3 and 1 (each within the scatter of the next); then compound 2.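

In this assay, 2-chlorophenyl in place of 4-(trifluoromethyl)phenyl, on the aromatic carbon between two ring nitrogen atoms, gives a 3.6-fold lower number from compound 2 to compound 3 (0.55 log units; beyond the scatter). This shows that the number responds to the group at this position, which compounds 1 and 2 could not show, as they differ in two places. With 2-chlorophenyl held constant, 2-aminophenyl in place of hydroxy on the amide-type nitrogen gives a 1.2-fold lower number from compound 1 to compound 3 (0.09 log units; within the scatter), so this read-out does not separate those two groups when this aryl group is present, and no measurement shown offers an explanation for either step.

The step changes both the substituent and its place on the phenyl ring, so a compound with 4-chlorophenyl or 2-(trifluoromethyl)phenyl would be needed to tell whether the chlorine or its placement matters. From the compounds shown here alone, it also remains open whether hydroxy and 2-aminophenyl would stay within the scatter of each other with 4-(trifluoromethyl)phenyl on the ring, or whether a longer chain would alter the size of the aryl step.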